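Expected metabolic stability of compound 4 from three measured analogues

The source may hold more compounds than are shown below. What is called first, only, known or untested is meant among the compounds shown, and "the series" means these compounds.

Compound 1 `COc1ccc(OC)c(-c2cc(C3=Nc4c(C(C)(C)C)nn(CCCO)c4C(=O)NC3)ccc2OC)c1`: 1.02 h
Compound 2 `COc1ccc(-c2cc(C3=Nc4c(C(C)(C)C)nn(CCCO)c4C(=O)NC3)ccc2OC)c(OC)c1`: 2 h
Compound 3 `COc1ccc(C2=Nc3c(C(C)(C)C)nn(CCCO)c3C(=O)NC2)cc1-c1ccccc1SC`: 0.85 h

In an ADME assay on microsomes from liver (Homo sapiens) for metabolic stability (a higher number here means that the compound lasts longer, a lower number that the compound disappears faster), compound 2 holds the highest of the three numbers, though the step of a 2.0-fold higher number from compound 1 to compound 2 (0.29 log units; within the scatter) stays within the scatter and only the gap to compound 3, a 2.4-fold lower number from compound 2 to compound 3 (0.37 log units; beyond the scatter), lies beyond it. Compound 4 `COc1ccc(C2=Nc3c(C(C)(C)C)nn(CCCO)c3C(=O)NC2)cc1-c1cnc(N(C)C)cc1C` is not yet measured; it differs from compound 2 by 6-(dimethylamino)-4-methylpyridin-3-yl in place of 2,4-dimethoxyphenyl on an aromatic carbon. Among the measured compounds shown here, no measured step swaps the aryl group for an aza-aromatic one, so the nearest guide is the modest loss seen in a 2.4-fold lower number from compound 2 to compound 3 (0.37 log units; beyond the scatter) and the flat step a 1.2-fold lower number from compound 1 to compound 3 (0.08 log units; within the scatter). A small decrease or no change beyond the scatter is therefore expected in this assay, as a 1.4-fold lower number from compound 2 to compound 4 (0.15 log units; within the scatter). Compound 4 is estimated at 1.4 h, within 0.6 h to 3.2 h.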

Compound 4, half-life: 0.7 h
Beside the measured number, compound 4's estimate is 2.0-fold (0.30 log units) above it; the measured number falls inside the stated range.
By their numbers in this assay, from the lowest: compounds 4, 3, 1 and 2 (each within the scatter of the next, the first and the last beyond it).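

Among the compounds shown here, at this aromatic carbon in this assay, a pyridine ring carrying dimethylamino and methyl groups gives a 2.9-fold lower number from compound 2 to compound 4 (0.46 log units; beyond the scatter) and so stands apart from 2,4-dimethoxyphenyl, the first such change of ring type. It stays within the scatter of the other two aryl groups, with a 1.2-fold lower number from compound 3 to compound 4 (0.08 log units; within the scatter) and a 1.5-fold lower number from compound 1 to compound 4 (0.16 log units; within the scatter) as the steps. Nothing measured here gives a reason for these steps.

From the compounds shown here alone, because the ring nitrogen, dimethylamino and methyl groups enter together, their separate contributions remain open. Going by these compounds, it is also open whether a morpholine in place of the dimethylamino group would change the half-life.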